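Swapping hydroxymethyl for formyl on a phenol-bearing terpenoid

A few compounds are considered here, and "the series" means these few. Any claim that something is new, unique, unknown or untested is made for them only; others in the source may bear on it.

Compound 1 `C=C[C@@](C)(/C=C/c1ccc(O)cc1)CC/C=C/C(=O)c1ccccc1`: > 43400 nM (a limit of the assay)
Compound 2 `C=C[C@@](C)(/C=C/c1ccc(O)c(CO)c1)CCC=C(C)C`: 16400 nM

Of the compounds shown here, two have been tested so far in a functional assay on NALM-6 cells (Homo sapiens) for cytotoxicity, with a stated time of 72 h; a higher number here means that more compound is needed for the effect, a lower number that less compound is needed. Compound 1 gives > 43400 nM, which is a limit of the assay and not a number. For the measured compounds named here, compound 2 gives 16400 nM, and this is the only actual number, so it has no measured neighbour to be ranked against.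

The next compound, compound 3 `C=C[C@@](C)(/C=C/c1ccc(O)c(C=O)c1)CCC=C(C)C`, keeps the core of compound 2 and changes one group. It carries formyl in place of hydroxymethyl on an aromatic carbon, ortho to a hydroxy group and meta to a large group: formyl in place of hydroxymethyl on an aromatic carbon.

Going by the values given here, no measured pair shows what this exchange does, so the expectation is anchored only on compound 2 at 16400 nM. A modest move in this assay is expected, towards less compound being needed, and a large jump is not anticipated. The expected step is a 2.1-fold lower number from compound 2 to compound 3 (0.31 log units; beyond the scatter). For compound 3 the estimated value is 8000 nM, with an expected range from 3000 nM to 22000 nM.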

Compound 3, half-maximal effective concentration: 11200 nM
Compound 3: middle estimate off by 1.4-fold (0.15 log units), on the low side; low and high end bracket the measured number.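

In this assay, formyl in place of hydroxymethyl on the aromatic carbon ortho to a hydroxy group gives a 1.5-fold lower number from compound 2 to compound 3 (0.17 log units; within the scatter), a step within the scatter, so compound 2 and compound 3 cannot be told apart. For the compounds shown here, this is the first measured pair, and it shows that this position accepts formyl, which has no hydrogen-bond donor where hydroxymethyl has one, without a change that this assay can resolve. Compound 1 stands at a limit, which is not a number, so it gives no measured step to either compound: the limit of > 43400 nM in this assay, at which 1 of the 3 values shown sits.

The compounds shown leave open whether this position tolerates only these two groups or also a carboxylic acid, an aminomethyl group or a longer chain ending in a hydroxy group. They also leave open whether the silence of this exchange would hold on a different core, and whether any group at this position could move the number beyond the scatter in this assay.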